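This account rests on a few compounds, and the source may have more. Where it says the series, first, only, none or still open, it means among the compounds named here.

Measured so far in a functional assay on HEK293 cells for agonist activity at Free fatty acid receptor 1 (Homo sapiens), read by calcium flux; on this read-out lower numbers stand for an effect already at smaller amounts and higher numbers for an effect only at larger amounts of compound:
compound 1 `CCCCCCCOc1ccc(C(CC(=O)O)c2ccccc2)cc1` — 4.26 uM
compound 2 `O=C(O)CC(c1ccccc1)c1ccc(OCCCC(F)(F)F)cc1` — 3.16 uM
compound 3 `C/C=C/COc1ccc(C(CC(=O)O)c2ccccc2)cc1` — 2.71 uM

The three compounds share one core and differ only in the chain on the ether oxygen. The steps between them are all small: a 1.3-fold lower number from compound 1 to compound 2 (0.13 log units; within the scatter), a 1.6-fold lower number from compound 1 to compound 3 (0.20 log units; within the scatter) and a 1.2-fold lower number from compound 2 to compound 3 (0.07 log units; within the scatter). Compound 3 has the smallest number of the three, but both steps leading to it sit within the scatter, so the three compounds cannot be separated on these data.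

Compound 4 `C=C(C)CCOc1ccc(C(CC(=O)O)c2ccccc2)cc1` is the next member. The change from compound 3 is 2-methylprop-2-en-1-yl in place of prop-1-en-1-yl on a saturated chain carbon bound to an oxygen on an aromatic ring. Among the compounds with values here, the steps that bear on it are the two that also exchanged the chain on the carbon bound to the ether oxygen, from compound 1 to compound 3 and from compound 2 to compound 3, both within the scatter; the step from compound 1 to compound 2, further out on the chain, was likewise within the scatter. Nothing among these exchanges has moved this assay beyond its scatter, so for compound 4 no step beyond the scatter is expected in this assay, an expected 1.0-fold higher number from compound 3 to compound 4 (0.01 log units; within the scatter). The estimate for compound 4 in this assay is 2.8 uM, with a range from 1.4 uM to 5.6 uM.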

Compound 4, concentration for half-maximal effect: 2.71 uM
Estimate against measurement, compound 4: 1.0-fold (0.01 log units) above; low and high end bracket the measured number.
By their numbers in this assay, from the lowest: compounds 3, 4, 2 and 1 (each within the scatter of the next).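

In this assay, the exchange of prop-1-en-1-yl (3 heavy atoms) for 2-methylprop-2-en-1-yl (4 heavy atoms), on a saturated chain carbon bound to an oxygen on an aromatic ring, gives no change at the digits printed from compound 3 to compound 4 (within the scatter); a larger chain with a methyl substituent on its double bond therefore reads the same here as the smaller unbranched one. The comparisons with the saturated chains agree, with a 1.2-fold lower number from compound 2 to compound 4 (0.07 log units; within the scatter) and a 1.6-fold lower number from compound 1 to compound 4 (0.20 log units; within the scatter), so compound 4 cannot be separated from compound 1 or compound 2 either. Across these four compounds, then, every chain exchange on the ether oxygen stays within the scatter, and none goes against this; nothing available explains why the read-out stays level across these chains.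

Open, from the compounds shown here alone, is whether a chain ending in an amine, a hydroxyl group or a phenyl ring would give a step beyond the scatter at this place. Also open, going by these compounds, is whether a much longer chain would do so, and whether the flat read-out holds once the carboxylic acid of the shared core is replaced by an amide.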